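The source may hold more compounds than are shown below. What is called first, only, known or untested is meant among the compounds shown, and "the series" means these compounds.

In an ADME assay on CCRF-HSB-2 cells (Homo sapiens) for cytotoxicity, with a stated time of 7 days (a lower number here means that less compound is tolerated, a higher number that more compound is tolerated), compound 1 `CC(C)CSc1nc(N)nc2c1ncn2/C=C1/CC1(CO)CO` gives 60000 nM. Compound 2 `CC(C)CNc1nc(N)nc2c1ncn2/C=C1/CC1(CO)CO` reaches only a limit of that measurement, > 20000 nM. Compound 3 `CN(C)c1nc(N)nc2c1ncn2/C=C1/CC1(CO)CO` likewise reaches only a limit, > 20000 nM, so it stands at the edge of what could be read. Because of the limit of > 20000 nM in this assay, at which 2 of the 3 values shown sit, the steps a step that the limit leaves unreadable from compound 1 to compound 2, a step that the limit leaves unreadable from compound 1 to compound 3 and a step that the two limits leave unreadable from compound 2 to compound 3 cannot be sized. Compound 4 `CSc1nc(N)nc2c1ncn2/C=C1/CC1(CO)CO` differs from compound 3 in one place: methylsulfanyl in place of dimethylamino on an aromatic carbon. Within the data shown here, since none of the measured steps can be read, no step beyond the scatter in either direction is expected for this change in this assay. Compound 4 is therefore expected to give about 50000 nM, within the range 20000 nM to 150000 nM. The expected step that the limit leaves unreadable from compound 3 to compound 4 is an estimate only.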

Compound 4, half-maximal cytotoxic concentration: > 100000 nM
Compound 4 was reported as a limit; the forecaster's own chance of this, stated with the estimate: 50%; at least 2.0-fold (0.30 log units) between middle value and limit.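

In this assay, among these compounds, the change from isobutylsulfanyl to methylsulfanyl gives the first step at this position that can be sized, if only by its floor: hydrogen in place of isopropyl on a saturated chain carbon bound to a sulfur gives an at least 1.6-fold higher number from compound 1 to compound 4 (0.22 log units; that floor lies within the scatter). This floor does not establish a real change between the two sulfur-linked compounds, although the true step may be larger. The steps from compound 2 and compound 3 to compound 4 cannot be read. Still open, as far as these compounds go, is where an ethylsulfanyl chain would fall, and how a plain amino group on this aromatic carbon would compare.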